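The source may report more compounds than this note shows. Statements on the series, on what has been measured and on what is new or still open speak of the compounds shown alone.

Compound 1, `CCCN(Cc1ccc(OCCN2C(=O)CCC2=O)c(C)c1)[C@@H](CC(=O)O)c1ccc(Cl)cc1`, is the better of the two measured compounds in an ADME assay on liver (Mus musculus) for metabolic stability, read by LC-MS, using microsomes and NADPH; a lower number here means that less of the compound is left, a higher number that more of the compound is left: compound 1 gives 97%. Its mirror-image partner compound 2, `CCCN(Cc1ccc(OCCN2C(=O)CCC2=O)c(C)c1)[C@H](CC(=O)O)c1ccc(Cl)cc1`, gives 69% in this assay. Within the data shown here, the only measured step is a number 28 percentage points lower from compound 1 to compound 2 (beyond the scatter), and the single thing that separates those two compounds is the fact that compounds 1 and 2 differ only in the configuration as drawn. The unmeasured compound 3, `Cc1cc(CN(CC2CCCC2)[C@@H](CC(=O)O)c2ccc(Cl)cc2)ccc1OCCN1C(=O)CCC1=O`, keeps the configuration of compound 1 and instead changes the group on the amine nitrogen: cyclopentyl in place of ethyl on a saturated chain carbon bound to an amine nitrogen. Among the measured compounds shown here, no measured step swaps one alkyl chain for another, so the one step on record, a change of configuration alone, gives no direct guide to how cyclopentyl in place of ethyl will read in this assay. The expectation for compound 3 therefore rests on compound 1 sitting high, with 97%, and allows a step of a number 12 percentage points lower from compound 1 to compound 3 (beyond the scatter), which is expected to be small or within the scatter. Compound 3 is estimated at 85%, with a range from 55% to 99%.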

Compound 3, percent of the compound remaining: 69%
For compound 3 the middle estimate is 16 percentage points above the measured one; low and high end bracket the measured number.
By their numbers in this assay, from the lowest: compounds 2 and 3 (each within the scatter of the next); then compound 1.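

Compound 3 is the first change shown at the amine nitrogen, and it shows that this position matters in this assay: with the configuration of compound 1 kept, cyclopentyl in place of ethyl on a saturated chain carbon bound to an amine nitrogen gives a number 28 percentage points lower from compound 1 to compound 3 (beyond the scatter). Seen another way, propyl becomes cyclopentylmethyl, so the high reading of compound 1 is tied to the group on the nitrogen as well as to the configuration, the only difference the earlier pair could show. Nothing on record gives a reason for this drop.

The compounds shown leave open whether the lower number goes with the ring itself or simply with the added carbons, a question that an open pentyl chain in place of propyl would address, and whether a smaller cyclopropylmethyl group would read closer to compound 1. They also leave open how the mirror-image form of compound 3 would read, as the effect of configuration is known only for the propyl pair, compound 1 and compound 2.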